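This account rests on a few compounds, and the source may have more. Where it says the series, first, only, none or still open, it means among the compounds named here.

Measured so far in a functional assay on HCT-116 cells (Homo sapiens) for inhibition, read by luminescence and resazurin assay, with a stated time of 3 days; on this read-out lower numbers stand for stronger inhibition and higher numbers for weaker inhibition:
- compound 1 `CN1CCN(c2nc(NCc3ccc(NC(=O)c4ccc(F)cc4)cc3)c3ccccc3n2)CC1`: 1800 nM
- compound 2 `CNc1nc(NCc2ccc(NC(=O)c3ccc(F)cc3)cc2Cl)c2ccccc2n1`: 2000 nM

Among the compounds with values here, compound 2 holds the higher of the two numbers so far, but its neighbour compound 1 sits within the scatter of it, so the two cannot be ranked on these values.

Compound 3 `CNc1nc(NCc2ccc(NC(=O)c3ccc(F)cc3)cc2)c2ccccc2n1` has not yet been measured in this assay. It differs from compound 2 in a single place: hydrogen in place of chloro on an aromatic carbon — hydrogen in place of chloro on an aromatic carbon, ortho to a large group and meta to the ((4-fluorophenyl)carbonyl)amino group. Within the data shown here, no step between measured compounds isolates this change, and the only other comparison available, compound 1 against compound 2, differs at the core as well, so it gives no direct reading on the chloro.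

Among the measured compounds shown here, with no measured step to lean on, the expected change is none beyond the scatter. Compound 3 is therefore estimated at 2200 nM in this assay, within 900 nM to 5500 nM, a step of a 1.1-fold higher number from compound 2 to compound 3 (0.04 log units; within the scatter) that would leave it alongside the two measured compounds.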

Compound 3, half-maximal inhibitory concentration: 1600 nM
Compound 3: middle estimate off by 1.4-fold (0.14 log units), on the high side, and the stated range covers the measured number.
By their numbers in this assay, from the lowest: compounds 3, 1 and 2 (each within the scatter of the next).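

In this assay, hydrogen in place of chloro on the aromatic carbon, ortho to a large group and meta to the ((4-fluorophenyl)carbonyl)amino group, gives a 1.3-fold lower number from compound 2 to compound 3 (0.10 log units; within the scatter); the chloro therefore makes no readable difference at this position. Within the data shown here, the new compound also gives the first one-place reading at the other site, where methylamino in place of 4-methylpiperazin-1-yl gives a 1.1-fold lower number from compound 1 to compound 3 (0.05 log units; within the scatter), so neither change separates the compounds on this read-out. Nothing measured here bears on a cause for either result.

Still open, on these data alone, is whether a different group on that aromatic carbon, such as methoxy or a carboxylic acid, would shift the number beyond the scatter. Equally open, as far as these compounds go, is whether a primary amine or a longer alkyl chain in place of methylamino would do so.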